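The source may hold more compounds than are shown below. What is called first, only, known or untested is meant among the compounds shown, and "the series" means these compounds.

Compound 1, `O=c1[nH]c(=O)n([C@H]2C[C@H](O)[C@@H](COP(=O)(O)O)O2)cc1Br`, is the starting point of the series. In a functional assay on L1210 cells (Mus musculus) for antiproliferative activity (a lower number here means a stronger inhibitor, a higher number a weaker inhibitor), compound 1 gives 457 ug/mL. This is the only numerical result among the two compounds measured here. Compound 2, `COP1(=O)OC[C@H]2O[C@@H](n3cc(Br)c(=O)[nH]c3=O)C[C@@H]2O1`, returns only a limit in this assay, > 100 ug/mL, and no number can be drawn from it. Of the two results in this assay, one is the limit of > 100 ug/mL in this assay, at which 1 of the 2 values shown sits. Going by the values given here, no two measured compounds differ in a single place, so no measured step is available to calibrate the next change. Compound 3, `O=c1[nH]c(=O)n([C@H]2C[C@H](O)[C@@H](COP(=O)(O)O)O2)cc1C(F)(F)F`, differs from compound 1 in one place: trifluoromethyl in place of bromo on an aromatic carbon. For this change, a 46-fold lower number from compound 1 to compound 3 (1.66 log units; beyond the scatter) is expected in this assay, in the direction of stronger inhibition and beyond the usual scatter. Compound 3 is accordingly estimated at 10 ug/mL, with a range from 1 ug/mL to 100 ug/mL.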

Compound 3, concentration for 50% inhibition: 38 ug/mL
Beside the measured number, compound 3's estimate is 3.8-fold (0.58 log units) below it; measured number inside the range.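

Going by these compounds alone, at this position, on an aromatic carbon of the shared core, the exchange of bromo for trifluoromethyl is the first single-place change with a measured size in this assay: a 12-fold lower number from compound 1 to compound 3 (1.08 log units; beyond the scatter). The step runs toward stronger inhibition and lies beyond the scatter, so this position is shown to respond to a change of substituent, though only a single pair supports this. Compound 2 adds no step, since its result is a limit and not a number: the limit of > 100 ug/mL in this assay, at which 1 of the 3 values shown sits.

On these data alone, whether a methyl, a chlorine or a nitrile at this position would move the number in the same direction remains open. Also open, as far as these compounds go, is whether the same exchange would hold on the core of compound 2, and the data give no cause for the step.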